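Lipophilicity notes: pyridin-3-yl replacing 4-hydroxyphenyl at the thiazolidinone

The source may hold more compounds than are shown below. What is called first, only, known or untested is meant among the compounds shown, and "the series" means these compounds.

Compound 2 `O=C(CN1C(=O)c2ccccc2C1=O)NN1C(=O)CSC1c1ccc(O)cc1` gives 2.4 in a physicochemical assay for lipophilicity, in phosphate buffer, measured as octanol-water partition, with a stated time of 24 h (on this read-out higher numbers stand for higher lipophilicity and lower numbers for lower lipophilicity), the highest of the three numbers; compound 1 `O=C(CN1C(=O)c2ccccc2C1=O)NN1C(=O)CSC1c1ccccc1` gives 2.23 and compound 3 `COc1cc(C2SCC(=O)N2NC(=O)CN2C(=O)c3ccccc3C2=O)ccc1O` gives 1.31. The step of a number 0.17 log units higher from compound 1 to compound 2 (within the scatter) stays within the scatter, whereas a number 1.09 log units lower from compound 2 to compound 3 (beyond the scatter) and a number 0.92 log units lower from compound 1 to compound 3 (beyond the scatter) both lie beyond it. Compound 4 `O=C(CN1C(=O)c2ccccc2C1=O)NN1C(=O)CSC1c1cccnc1` differs from compound 2 by pyridin-3-yl in place of 4-hydroxyphenyl on a saturated ring carbon. Among the measured compounds shown here, no measured step swaps one aromatic ring for another; a number 0.17 log units higher from compound 1 to compound 2 (within the scatter) shows only that the hydroxy made little difference, so the removal of the hydroxy alone would not be expected to move this assay. For the measured compounds named here, the nitrogen-containing ring has no precedent here, and the estimate is correspondingly uncertain. Compound 4 is expected to give 1.4, between 0.8 and 2, an expected step of a number 1.00 log units lower from compound 2 to compound 4 (beyond the scatter).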

Compound 4, partition coefficient: 1.25
Beside the measured number, compound 4's estimate is 0.15 log units above it; the measured number falls inside the stated range.
By their numbers in this assay, from the lowest: compounds 4 and 3 (each within the scatter of the next); then compounds 1 and 2 (each within the scatter of the next).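

In this assay the saturated ring carbon responds to the identity of the ring itself: pyridin-3-yl gives a number 1.15 log units lower from compound 2 to compound 4 (beyond the scatter) and a number 0.98 log units lower from compound 1 to compound 4 (beyond the scatter) while hydroxy on the phenyl ring alone stayed within the scatter. Against 4-hydroxy-3-methoxyphenyl the same ring gives a number 0.06 log units lower from compound 3 to compound 4 (within the scatter) and so these two groups are not separated on this read-out. Nothing available accounts for the shift.

Still open, from the compounds shown here alone, is whether pyridin-2-yl or pyridin-4-yl at this carbon would fall with compound 4 or with compound 2. An aminophenyl or carboxyphenyl group there is equally undecided.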